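The source may report more compounds than this note shows. Statements on the series, on what has been measured and on what is new or still open speak of the compounds shown alone.

Measured compounds:
compound 1 `COc1ccc(OC)c(/C=C/S(=O)(=O)Cc2ccc(OC)c(N)c2)c1` with 750 nM in a functional assay on DU-145 cells (Homo sapiens) for cytotoxicity, read by trypan blue exclusion, with a stated time of 96 h; on this read-out lower numbers stand for stronger inhibition and higher numbers for weaker inhibition
compound 2 `COc1cc(OC)c(/C=C/S(=O)(=O)Cc2ccc(OC)cc2[N+](=O)[O-])c(OC)c1` with 20000 nM in this assay
compound 3 `COC(=O)[C@H](C)Nc1cc(CS(=O)(=O)/C=C/c2c(OC)cc(OC)cc2OC)ccc1OC` with 750 nM in this assay

Among these three, compound 3 stands level with compound 1 at the digits shown, the two together giving the lowest numbers, while compound 2 lies far above both, beyond the scatter. Going by the values given here, compound 3 shares its trimethoxy-bearing styryl part with compound 2 but carries a substituted amino group on the other ring, and no single-change pair between the measured compounds can be traced.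

Compound 4 `COc1cc(OC)c(/C=C/S(=O)(=O)Cc2ccc(OC)c(NC(C(=O)O)c3ccc(Cl)cc3)c2)c(OC)c1` keeps the whole of compound 3 except at one position: carboxy(4-chlorophenyl)methyl in place of 1-(methoxycarbonyl)ethyl on a nitrogen on an aromatic ring. Among the compounds with values here, no measured pair shows what such an exchange does here. With compound 3 at 750 nM as the only anchor, the account expects at most a modest shift in this assay toward weaker inhibition, a step of a 2.0-fold higher number from compound 3 to compound 4 (0.30 log units; within the scatter) that is estimated and could still lie within the scatter. Compound 4 is therefore expected to give about 1500 nM, estimated between 400 nM and 6000 nM.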

Compound 4, half-maximal inhibitory concentration: 400 nM
Compound 4: the middle estimate sits 3.8-fold (0.57 log units) above what was measured; measured number inside the range.
By their numbers in this assay, from the lowest: compounds 4, 1 and 3 (each within the scatter of the next); then compound 2.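

On the nitrogen on the aromatic ring, the exchange of 1-(methoxycarbonyl)ethyl for carboxy(4-chlorophenyl)methyl gives a 1.9-fold lower number from compound 3 to compound 4 (0.27 log units; within the scatter) in this assay. Going by these compounds alone, the position therefore takes a substituent with more heavy atoms, an added six-membered aromatic ring and a hydrogen-bond donor, and the number stays within the scatter, which the earlier compounds could not show. No available evidence bears on why the number holds across this exchange.

Within the data shown here, the single step changes the ester to a carboxy group and the methyl to a 4-chlorophenyl ring at once, so the contribution of each part stays unresolved, and the two could even offset each other. From the compounds shown here alone, how a plain phenyl ring in place of the 4-chlorophenyl, or an amide in place of the carboxy group, would read at this position remains open.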